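The source may report more compounds than this note shows. Statements on the series, on what has been measured and on what is new or still open speak of the compounds shown alone.

Measured in a functional assay on SK-OV-3 cells (Homo sapiens) for antiproliferative activity, read by MTT assay, with a stated time of 72 h; a lower number here means a stronger inhibitor, a higher number a weaker inhibitor:
Compound 1 `O=C(CCc1cccc2c1B(O)OC2)Nc1ccc(I)cc1`: 51000 nM
Compound 2 `CCOC(=O)c1ccc(NC(=O)CCc2cccc3c2B(O)OC3)cc1`: > 100000 nM

Compound 2 reads > 100000 nM, which is a limit of the assay and not a number. Its place on the scale is therefore known only as the limit of > 100000 nM in this assay, at which 1 of the 2 values shown sits. For the measured compounds named here, compound 3 `O=C(CCc1cccc2c1B(O)OC2)Nc1ccc(-c2ccccc2)cc1` keeps the shared core and the amide chain of compound 2, and the one change is phenyl in place of ethoxycarbonyl on an aromatic carbon, para to a large group: phenyl in place of ethoxycarbonyl on an aromatic carbon.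

Going by the values given here, only one measured step bears on this place on the ring, and it is an at least 1.9-fold higher number from compound 1 to compound 2 (0.29 log units; that floor lies within the scatter). That step swaps ethoxycarbonyl for iodo and does not clearly pass the scatter. Among the compounds with values here, it therefore gives little guidance on size, and no phenyl compound has been measured for comparison. Within the data shown here, compound 1, at 51000 nM, is the only exact number to lean on, so no step beyond the scatter is expected in this assay, and weak activity is expected to persist. The estimate corresponds to an at least 1.6-fold lower number from compound 2 to compound 3 (0.22 log units; that floor lies within the scatter), an expected change that remains small. For compound 3 the expected value is 60000 nM, with an estimated range from 25000 nM to 100000 nM.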

Compound 3, half-maximal inhibitory concentration: 48000 nM
Estimate against measurement, compound 3: 1.3-fold (0.10 log units) above, within the range that was stated.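

In this assay, for the compounds shown here, the change shows an at least 2.0-fold lower number from compound 2 to compound 3 (0.31 log units; beyond the scatter), the first step at this place on the ring to pass the scatter, so the group at this position can affect the reading in this cell assay. The full size of that step cannot be read because compound 2 carries a limit of the assay and not an exact number: the limit of > 100000 nM in this assay, at which 1 of the 3 values shown sits.

Phenyl and iodo give readings that cannot be told apart, with a 1.1-fold lower number from compound 1 to compound 3 (0.03 log units; within the scatter), so a whole aromatic ring and a single iodine atom at this position serve equally well here, while ethoxycarbonyl is the only one of the three groups that reaches the limit.

Three groups at one position are too few to show which feature of a group governs the reading, and an amine or a carboxylic acid in the same place would test the result with quite different atoms. From the compounds shown here alone, it also remains open whether a longer chain in the amide link to the shared core would shift the readings of compound 1 and compound 3, or whether the link and the shared core tolerate change at all.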